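The source may report more compounds than this note shows. Statements on the series, on what has been measured and on what is new or still open speak of the compounds shown alone.

Measured so far in an assay on isolated protein for inhibition of ribosomal protein S6 kinase alpha-1 (Homo sapiens), read by mobility shift assay, tested at 30 uM; a higher number here means more inhibition at the concentration tested (going by the name of the read-out), a lower number less inhibition:
compound 1, `COc1ccc(-c2cc3[nH]nc(N)c3c(=O)[nH]2)cc1`, gives 7%
compound 2, `CN1CCN(c2ccc(-c3cc4[nH]nc(N)c4c(=O)[nH]3)cc2)CC1`, gives 26%
compound 3, `COc1ccc(-c2cc3nn(-c4ccccc4)c(N)c3c(=O)[nH]2)cc1`, gives 4%

Compound 1 and compound 2 differ in one place: 4-methylpiperazin-1-yl in place of methoxy on an aromatic carbon. That step is a number 19 percentage points higher from compound 1 to compound 2 (beyond the scatter). Compound 3 stands lowest of the three; its gap to compound 1 lies within the scatter, its gap to compound 2 beyond it. The difference between the core of compound 3 and that of compound 1 is not broken down here.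

Compound 4, `CN1CCN(c2ccc(-c3cc4nn(-c5ccccc5)c(N)c4c(=O)[nH]3)cc2)CC1`, is not yet measured. It differs from compound 3 by 4-methylpiperazin-1-yl in place of methoxy on an aromatic carbon, the same change as from compound 1 to compound 2. For compound 4 the expected step in this assay is a number 14 percentage points higher from compound 3 to compound 4 (beyond the scatter), resting on compound 3 at 4% and on the earlier step of a number 19 percentage points higher from compound 1 to compound 2 (beyond the scatter). As far as these compounds go, whether the step carries over to the other core is untested, so the range is kept wide. The estimate for compound 4 in this assay is 18%, between 2% and 38%.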

Compound 4, a percentage reported as inhibition, at one concentration (the size of the read-out at that concentration, not a potency): 19%
The estimate for compound 4 lay 1 percentage points below the measured number; the measured number falls inside the stated range.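

In this assay the change gives a number 15 percentage points higher from compound 3 to compound 4 (beyond the scatter), and the step agrees with the one on the other core: the same change on two cores in this assay, a number 19 percentage points higher (beyond the scatter) from compound 1 to compound 2 and a number 15 percentage points higher (beyond the scatter) from compound 3 to compound 4, 4 percentage points apart, within the scatter of two such steps. Across these two cores, then, the exchange of methoxy for 4-methylpiperazin-1-yl carries over with no difference that can be told from the scatter. This rests on a single pair per core, read at one concentration on one kinase, so it shows neither a rule for other cores nor anything about potency.

Open, as far as these compounds go, is which part of 4-methylpiperazin-1-yl goes with the step, a question that morpholine or an open-chain amine in the same place would address. Also open, from the compounds shown here alone, is whether the step holds with a small alkyl group, such as methyl, in place of the phenyl ring of compound 3.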